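This account rests on a few compounds, and the source may have more. Where it says the series, first, only, none or still open, it means among the compounds named here.

Compound 1 `CCCCNc1nc(N)nc2c1CNCC2` gives 7.2 uM in an assay on HEK293 cells for agonist activity at Toll-like receptor 8 (Homo sapiens), read by a luciferase reporter, with a stated time of 6 h; a lower number here means that less compound is needed, a higher number that more compound is needed for the effect. Compound 2 `CCCCNc1nc(N)nc2c1CN(C(C)=O)CC2` gives 0.5 uM in this assay.

Compound 2 stands lowest of the two numbers measured; its nearest neighbour is compound 1, at a higher number, and the step of a 14-fold lower number from compound 1 to compound 2 (1.16 log units; beyond the scatter) puts a large difference between them for the change of acetyl in place of hydrogen on an amine nitrogen in a ring.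

Compound 3 `CCCCNc1nc(N)nc2c1CN(C(=O)c1ccccc1)CC2` differs from compound 2 by phenyl in place of methyl on a carbonyl carbon. Among the measured compounds shown here, no measured step speaks to a phenyl in place of methyl on a carbonyl carbon; the only step known, a 14-fold lower number from compound 1 to compound 2 (1.16 log units; beyond the scatter), concerns the presence of the acetyl itself, which compound 3 keeps in the form of a benzoyl. The expectation is therefore for a step of a 1.4-fold higher number from compound 2 to compound 3 (0.15 log units; within the scatter) that stays near compound 2, with no change beyond the scatter clearly foreseen in either direction. Compound 3 is estimated at 0.7 uM, within a range from 0.15 uM to 3 uM.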

Compound 3, minimum effective concentration: 1.4 uM
The estimate for compound 3 lay 2.0-fold (0.30 log units) below the measured number; the range from low to high includes it.
By their numbers in this assay, from the lowest: compound 2; then compound 3; then compound 1.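

In this assay the group on this carbonyl carbon is shown to matter, as phenyl in place of methyl gives a modest change beyond the scatter (a 2.8-fold higher number from compound 2 to compound 3 (0.45 log units; beyond the scatter)). The amide-type nitrogen in the ring still tolerates the larger group, since benzoyl in place of hydrogen keeps a lower number than the free amine (a 5.1-fold lower number from compound 1 to compound 3 (0.71 log units; beyond the scatter)). Among the compounds shown, both acetyl and benzoyl therefore stand below hydrogen, with acetyl the lowest, and nothing available accounts for the difference between the methyl and the phenyl.

Open, on these data alone, is whether an ethyl or propyl group on the carbonyl carbon would stand nearer to the methyl or to the phenyl. Also open, as far as these compounds go, is how a benzyl group, or a phenyl carrying a methoxy group or a fluorine, would read here.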